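Replacing the amide side chain of compound 3

The source may report more compounds than this note shows. Statements on the series, on what has been measured and on what is new or still open speak of the compounds shown alone.

Compound 1 `Cn1ncc(Cl)c1-c1cc(C(=O)N[C@@H]2CN[C@H](CC(=O)O)C[C@H]2c2ccc(Cl)c(Cl)c2)oc1Cl`: 640 nM
Compound 2 `C=CC[C@@H]1C[C@@H](c2ccc(Cl)c(Cl)c2)[C@H](NC(=O)c2cc(-c3c(Cl)cnn3C)c(Cl)o2)CN1`: 160 nM
Compound 3 `Cn1ncc(Cl)c1-c1cc(C(=O)N[C@@H]2CN[C@H](CC(=O)NCCO)C[C@H]2c2ccc(Cl)c(Cl)c2)oc1Cl`: 40 nM

In a functional assay on LNCaP cells (Homo sapiens) for antiproliferative activity (a higher number here means a weaker inhibitor, a lower number a stronger inhibitor), compound 3 gives 40 nM, the lowest number of the three. Compound 4 `COCC[C@@H]1C[C@@H](c2ccc(Cl)c(Cl)c2)[C@H](NC(=O)c2cc(-c3c(Cl)cnn3C)c(Cl)o2)CN1` keeps the shared core but carries methoxymethyl in place of (2-hydroxyethyl)carbamoyl on a saturated chain carbon bound to a saturated ring carbon. Two measured steps end at this same amide chain. The larger, a 16-fold lower number from compound 1 to compound 3 (1.20 log units; beyond the scatter), starts from a carboxylic acid. The closer guide is compound 2, which also lacks a carbonyl in that chain: a 4.0-fold lower number from compound 2 to compound 3 (0.60 log units; beyond the scatter). Losing the amide should therefore reverse a modest step. The estimated change is a 3.0-fold higher number from compound 3 to compound 4 (0.48 log units; beyond the scatter). For compound 4, the expected value is 120 nM, with an estimated range of 45 nM to 320 nM.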

Compound 4, half-maximal inhibitory concentration: 250 nM
The estimate for compound 4 lay 2.1-fold (0.32 log units) below the measured number; low and high end bracket the measured number.
By their numbers in this assay, from the lowest: compound 3; then compounds 2 and 4 (each within the scatter of the next); then compound 1.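

In this assay the step of a 6.3-fold higher number from compound 3 to compound 4 (0.80 log units; beyond the scatter) shows that the oxygen of methoxymethyl does not make up for losing (2-hydroxyethyl)carbamoyl at this position, while a 1.6-fold higher number from compound 2 to compound 4 (0.19 log units; within the scatter) leaves methoxymethyl and vinyl not told apart. Methoxymethyl still improves on carboxy, with a 2.6-fold lower number from compound 1 to compound 4 (0.41 log units; beyond the scatter) as the step. Nothing measured here explains these differences. Still open, on these data alone, is whether the gain in compound 3 comes from the amide itself or from its terminal hydroxy, which a simple methyl amide on this chain could help separate.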